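Tetrahydroquinoline-2-carboxanilides: N-benzoylation and growth inhibition

The source may report more compounds than this note shows. Statements on the series, on what has been measured and on what is new or still open speak of the compounds shown alone.

Measured compounds:
compound 1 `O=C(Nc1ccccc1C(F)(F)F)C1CCc2ccccc2N1` 53300 nM
compound 2 `O=C(Nc1ccccc1C(F)(F)F)C1CCc2ccccc2N1C(=O)c1ccccc1` 5560 nM
compound 3 `O=C(Nc1cc(C(F)(F)F)cc(C(F)(F)F)c1)C1CCc2ccccc2N1` 8120 nM

Working notes. The read-out throughout is a functional assay on PC-3 cells (Homo sapiens) for cytotoxicity, read by sulforhodamine B assay, with a stated time of 72 h; a higher number here means a weaker inhibitor of growth, a lower number a stronger inhibitor of growth. Compound 1 is the unsubstituted parent and gives 53300 nM. Compound 2 carries the change benzoyl in place of hydrogen on a nitrogen on an aromatic ring in a ring and gives 5560 nM; the step of a 9.6-fold lower number from compound 1 to compound 2 (0.98 log units; beyond the scatter) is the only one in the set that can be counted against a single structural change.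

Compound 3 differs from compound 1 in the aryl amide part; the difference between the two cores is not broken down here. Compound 3 gives 8120 nM. Against compound 2 the two numbers lie within the scatter, so no order between them is claimed; against compound 1 the number of compound 3 is the lower one, beyond the scatter.

Compound 4 `O=C(Nc1cc(C(F)(F)F)cc(C(F)(F)F)c1)C1CCc2ccccc2N1C(=O)c1ccccc1` is not yet measured. It carries the change (benzoyl in place of hydrogen on a nitrogen on an aromatic ring in a ring). The place description is the same word for word as for the change from compound 1 to compound 2, so this is the same change applied to the core of compound 3. For the measured compounds named here, the only guide to its size is the measured step of a 9.6-fold lower number from compound 1 to compound 2 (0.98 log units; beyond the scatter); whether it carries over onto the core of compound 3 is untested, so a somewhat smaller step is taken as the middle expectation, with a wide range either way. On that basis compound 4 is expected to give 1100 nM in this assay, between 300 nM and 4000 nM, which would mean an estimated step of a 7.4-fold lower number from compound 3 to compound 4 (0.87 log units; beyond the scatter).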

Compound 4, concentration for 50% growth inhibition: 3500 nM
For compound 4 the middle estimate is 3.2-fold (0.50 log units) below the measured one, and the stated range covers the measured number.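

In this assay, benzoyl in place of hydrogen on a nitrogen on an aromatic ring in a ring again goes with a lower number, a 2.3-fold lower number from compound 3 to compound 4 (0.37 log units; beyond the scatter), so the direction of the change holds on both cores shown. The size of the step does not carry over unchanged: the same change on two cores in this assay, a 9.6-fold lower number (0.98 log units; beyond the scatter) from compound 1 to compound 2 and a 2.3-fold lower number (0.37 log units; beyond the scatter) from compound 3 to compound 4, 4.1-fold (0.62 log units) apart, beyond the scatter of two such steps

For the compounds shown here, with only two cores, which differ in the aryl amide part, these results show that the size of the step depends on the core in this pair of cores, but they do not show which feature of the aryl amide part accounts for the gap, nor how the step would behave on any further core.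

Still open, going by these compounds, is whether a smaller acyl group such as acetyl on the same nitrogen, or a benzoyl whose ring carries an amine or a carboxylic acid, would give steps that also differ between the two cores. Also open, on these data alone, is how the benzoyl step would behave on an aryl amide with a nitrile or a chlorine in place of trifluoromethyl, which would help to show how much of the gap between the two steps follows the aryl amide part.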